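Replacing the alkyne of compound 1 with a 2-chlorophenyl group

The source may hold more compounds than are shown below. What is called first, only, known or untested is meant among the compounds shown, and "the series" means these compounds.

In a functional assay on HCT-116 cells (Homo sapiens) for antiproliferative activity, with a stated time of 72 h (a lower number here means a stronger inhibitor, a higher number a weaker inhibitor), compound 1 `CCCCC#Cc1cc([C@@H]2O[C@H](CO)[C@@H](O)[C@H]2O)n2ncnc(N)c12` gives 2900 nM. Of the two numbers shown, compound 1 has the lowest; the nearest is compound 2 `Nc1ncnn2c([C@@H]3O[C@H](CO)[C@@H](O)[C@H]3O)cc(-c3ccc(F)cc3)c12`, which in this assay gives 42500 nM. Compound 3 `Cc1ccccc1-c1cc([C@@H]2O[C@H](CO)[C@@H](O)[C@H]2O)n2ncnc(N)c12` reaches only a limit of the assay, > 100000 nM, and gives no number. The third value thus sits at the limit (the limit of > 100000 nM in this assay, at which 1 of the 3 values shown sits).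

Compound 4 `Nc1ncnn2c([C@@H]3O[C@H](CO)[C@@H](O)[C@H]3O)cc(-c3ccccc3Cl)c12` has not yet been measured in this assay. It differs from compound 1 in one place: 2-chlorophenyl in place of hex-1-yn-1-yl on an aromatic carbon

For the measured compounds named here, two measured steps bear on this change. Exchanging the hex-1-yn-1-yl group for an aromatic ring gave a 15-fold higher number from compound 1 to compound 2 (1.17 log units; beyond the scatter) and an at least 34-fold higher number from compound 1 to compound 3 (1.53 log units; beyond the scatter). Between the two aromatic rings, an at least 2.3-fold higher number from compound 2 to compound 3 (0.37 log units; beyond the scatter) was seen. A 2-chlorophenyl group resembles the 2-methylphenyl of compound 3 more than the 4-fluorophenyl of compound 2, so a large rise in this assay is expected, as a 28-fold higher number from compound 1 to compound 4 (1.44 log units; beyond the scatter). Compound 4 is therefore estimated at 80000 nM, in the range 15000 nM to 300000 nM, with a real chance that only a limit is recorded.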

Compound 4, half-maximal inhibitory concentration: > 100000 nM
Compound 4 gave a limit, no number; the forecaster's own chance of this, stated with the estimate: 45%; at least 1.2-fold (0.09 log units) between middle value and limit.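

In this assay compound 4 gives only a limit, > 100000 nM, and no number. On this aromatic carbon, 2-chlorophenyl in place of hex-1-yn-1-yl gives an at least 34-fold higher number from compound 1 to compound 4 (1.53 log units; beyond the scatter), and 2-chlorophenyl in place of 4-fluorophenyl gives an at least 2.3-fold higher number from compound 2 to compound 4 (0.37 log units; beyond the scatter), so the drop seen with 2-methylphenyl is not confined to that one ring: a second 2-substituted phenyl group now falls beyond the number measured for compound 2. The step from compound 3 to compound 4 cannot be read, so chloro and methyl cannot be ranked here, as both compounds stand at the same limit: the limit of > 100000 nM in this assay, at which 2 of the 4 values shown sit.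

From the compounds shown here alone, it stays open whether a 4-chlorophenyl group would behave like 4-fluorophenyl or like 2-chlorophenyl at this place. Also open, going by these compounds, is how a shorter or longer alkyne chain, or an alkyne ending in an amine or a hydroxyl group, would compare with hex-1-yn-1-yl.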